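The source may hold more compounds than are shown below. What is called first, only, known or untested is meant among the compounds shown, and "the series" means these compounds.

Compound 1 `Cc1cc(C)nc(NS(=O)(=O)c2ccc(/N=C/c3c(Cl)c4ccccc4oc3=O)cc2)n1` places a 4,6-dimethylpyrimidin-2-yl group on a sulfonamide nitrogen attached to the core shown; in a functional assay on MCF7 cells (Homo sapiens) for cytotoxicity, read by CCK-8 assay, with a stated time of 48 h (on this read-out higher numbers stand for weaker inhibition and lower numbers for stronger inhibition), compound 1 gives 20 nM. Compound 2 `Cc1cc(NS(=O)(=O)c2ccc(/N=C/c3c(Cl)c4ccccc4oc3=O)cc2)no1` keeps the core of compound 1 and differs from it only in one way: 5-methyl-1,2-oxazol-3-yl in place of 4,6-dimethylpyrimidin-2-yl on a sulfonamide nitrogen. In this assay compound 2 gives 12 nM, and the change produced a 1.7-fold lower number from compound 1 to compound 2 (0.22 log units; within the scatter). Compound 3 `Cc1cc(C)nc(NS(=O)(=O)c2ccc(/N=C/c3c(Cl)c4cc(C(C)(C)C)cc(C(C)(C)C)c4oc3=O)cc2)n1` carries the same 4,6-dimethylpyrimidin-2-yl group on its sulfonamide nitrogen as compound 1, but its core differs from that of compound 1 in more than one place, and the difference between the two cores is not broken down here. In this assay compound 3 gives 8.8 nM, a number that lies close to that of compound 2 and somewhat below that of compound 1.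

Compound 4 `Cc1cc(NS(=O)(=O)c2ccc(/N=C/c3c(Cl)c4cc(C(C)(C)C)cc(C(C)(C)C)c4oc3=O)cc2)no1` has not yet been measured. It stands to compound 3 as compound 2 stands to compound 1: 5-methyl-1,2-oxazol-3-yl in place of 4,6-dimethylpyrimidin-2-yl on a sulfonamide nitrogen. The place is the same in both pairs, a sulfonamide nitrogen whose other neighbour is the sulfonyl sulfur, so this is the same change carried onto the core of compound 3. Because the earlier instance gave a 1.7-fold lower number from compound 1 to compound 2 (0.22 log units; within the scatter), the step expected from compound 3 to compound 4 in this assay is a 1.4-fold lower number from compound 3 to compound 4 (0.13 log units; within the scatter), a shift of comparable size that would itself remain within the scatter. Compound 4 is accordingly expected to give about 6.5 nM in this assay, with a likely range from 3 nM to 15 nM.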

Compound 4, half-maximal inhibitory concentration: 64 nM
The estimate for compound 4 lay 9.8-fold (0.99 log units) below the measured number; measured number above the stated range.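

In this assay, the exchange of 4,6-dimethylpyrimidin-2-yl for 5-methyl-1,2-oxazol-3-yl on a sulfonamide nitrogen, carried onto the second core, gave a 7.3-fold higher number from compound 3 to compound 4 (0.86 log units; beyond the scatter). The two instances of this one change do not agree, and its effect on the number depends on the core that carries it: the same change on two cores in this assay, a 1.7-fold lower number (0.22 log units; within the scatter) from compound 1 to compound 2 and a 7.3-fold higher number (0.86 log units; beyond the scatter) from compound 3 to compound 4, 12-fold (1.08 log units) apart, beyond the scatter of two such steps. Going by these compounds alone, this shows that, for these two cores, a step read on one cannot be transferred to the other, but with only two pairs it does not show which feature of the cores separates the two steps, nor how the change would behave on any further core.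

The two cores differ in more than one place, so the compounds shown leave open whether a single one of those differences is enough to reverse the step, which a core carrying only part of them could settle. They also leave open how other groups on the sulfonamide nitrogen, such as a thiazol-2-yl ring or a plain phenyl ring, would behave on the two cores, and whether they too would give steps that differ from one core to the other.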